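Swapping a Ring Substituent on a Cytotoxicity Series

The source may report more compounds than this note shows. Statements on the series, on what has been measured and on what is new or still open speak of the compounds shown alone.

For compound 1 `O=C1O/C(=C\Cn2cc(-c3ccccc3)nn2)C(OCc2ccccc2)=C1OCc1ccccc1`, an ADME assay on HEK293 cells (Homo sapiens) for cytotoxicity, read by MTT assay, with a stated time of 24 h (on this read-out lower numbers stand for stronger inhibition and higher numbers for weaker inhibition), reports only a limit, > 100000 nM, namely (the limit of > 100000 nM in this assay, at which 1 of the 3 values shown sits). Compound 2 `Cc1ccc(-c2cn(CCC3(O)NC(=O)C(OCc4ccccc4)=C3OCc3ccccc3)nn2)cc1` gives 45000 nM in this assay, and compound 3 `O=C1NC(O)(CCn2cc(C3=CCCCC3)nn2)C(OCc2ccccc2)=C1OCc1ccccc1` gives 70000 nM. Among the compounds with values here, the one measured change, a 1.6-fold higher number from compound 2 to compound 3 (0.19 log units; within the scatter), stays within the scatter, so compound 3 sits alongside compound 2 as the higher of the two numbers without being separated from it. Compound 4 `O=C1NC(O)(CCn2cc(Cc3ccccc3)nn2)C(OCc2ccccc2)=C1OCc1ccccc1` differs from compound 3 by benzyl in place of cyclohex-1-en-1-yl on an aromatic carbon. Within the data shown here, the only step bearing on this, another exchange of the group on the same aromatic carbon, was within the scatter, so no step beyond the scatter is expected in this assay. Compound 4 is therefore estimated at 60000 nM, between 25000 nM and 150000 nM. That means an expected step of a 1.2-fold lower number from compound 3 to compound 4 (0.07 log units; within the scatter).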

Compound 4, half-maximal inhibitory concentration: 86000 nM
Estimate against measurement, compound 4: 1.4-fold (0.16 log units) below, and the stated range covers the measured number.
By their numbers in this assay, from the lowest: compounds 2, 3 and 4 (each within the scatter of the next). At a limit, above all of these: compound 1.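

Benzyl now joins cyclohex-1-en-1-yl and 4-methylphenyl on this aromatic carbon of the five-membered ring, and in this assay the exchanges give a 1.2-fold higher number from compound 3 to compound 4 (0.09 log units; within the scatter) and a 1.9-fold higher number from compound 2 to compound 4 (0.28 log units; within the scatter). So the three groups, with an aromatic ring or a non-aromatic one, give numbers within the scatter of one another at this place. Nothing measured here gives a cause for these numbers.

Going by these compounds, whether an amine or a carboxylic acid on this carbon would move the number beyond the scatter remains open. The same holds for a longer chain of carbon atoms ending in a phenyl ring.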